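This account rests on a few compounds, and the source may have more. Where it says the series, first, only, none or still open, it means among the compounds named here.

Compound 1, `FC(F)(F)c1ccc(/C=C\c2cc3ccccc3nc2Cl)cc1`, was examined in a functional assay on MDA-MB-231 cells (Homo sapiens) for antiproliferative activity, read by sulforhodamine B assay, with a stated time of 72 h (a higher number here means a weaker inhibitor, a lower number a stronger inhibitor), where compound 1 gives 5360 nM. Two relatives share a closely related core but differ from compound 1 by a part of the molecule that is not broken down here. Compound 2, `COc1ccc2nc(Cl)c(/C=C\c3cccc(C(F)(F)F)c3)cc2c1`, gives 3280 nM in this assay, and compound 3, `COc1ccc2nc(Cl)c(/C=C\c3cc(C(F)(F)F)cc(C(F)(F)F)c3)cc2c1`, gives 4470 nM. The change from compound 2 to compound 3 is trifluoromethyl in place of hydrogen on an aromatic carbon, and it produced a 1.4-fold higher number from compound 2 to compound 3 (0.13 log units; within the scatter), so the two numbers cannot be told apart.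

Compound 4, `FC(F)(F)c1ccc(/C=C\c2cc3ccccc3nc2Cl)c(C(F)(F)F)c1`, has not yet been measured. It arises from compound 1 by trifluoromethyl in place of hydrogen on an aromatic carbon, the same kind of change as that from compound 2 to compound 3, though the new group sits ortho to a large group rather than meta to a large group, while in both cases it is meta to a trifluoromethyl group. Because the earlier step gave a 1.4-fold higher number from compound 2 to compound 3 (0.13 log units; within the scatter), compound 4 is expected to come out close to compound 1, with a 1.2-fold higher number from compound 1 to compound 4 (0.08 log units; within the scatter). The estimate for compound 4 in this assay is 6500 nM, spanning 3300 nM to 13000 nM.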

Compound 4, half-maximal inhibitory concentration: 41800 nM
Compound 4: middle estimate off by 6.4-fold (0.81 log units), on the low side; measured number above the stated range.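

In this assay, trifluoromethyl in place of hydrogen on an aromatic carbon gave a 7.8-fold higher number from compound 1 to compound 4 (0.89 log units; beyond the scatter), so compound 4 is a weaker inhibitor than compound 1. The same change therefore did not carry over with the same size from one core to the other: the same change on two cores in this assay, a 1.4-fold higher number (0.13 log units; within the scatter) from compound 2 to compound 3 and a 7.8-fold higher number (0.89 log units; beyond the scatter) from compound 1 to compound 4, 5.7-fold (0.76 log units) apart, beyond the scatter of two such steps. This does not show that the core alone sets the size of the step, since the new group in compound 4 is ortho to a large group, whereas in compound 3 it is meta to one, and two steps that differ in both core and place cannot separate the two or support a general rule.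

The compounds shown leave open how the core of compound 2 responds to a trifluoromethyl group ortho to a large group, which is the comparison that would separate core from place. They also leave open whether another group at that place on the core of compound 1, such as a nitrile or an amine, would give a step of similar size.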